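The compounds below may be only part of what the source reports. "The series", "measured", "known", "first", "only" and "open" are said of these compounds alone.

Working notes on the series. Compound 1 `C=CCn1ncc2c(CC)ncn2c1=O` carries the shared core with an ethyl group. In a functional assay for inhibition, with Homo sapiens as the target (on this read-out lower numbers stand for stronger inhibition and higher numbers for weaker inhibition), compound 1 gives only a limit of the assay, > 48000 nM. Compound 2 `C=CCn1ncc2c(CCC)ncn2c1=O` carries propyl in place of ethyl. In this assay compound 2 likewise gives only a limit, > 48000 nM. Among the compounds with values here, the single measured step, a step that the two limits leave unreadable from compound 1 to compound 2, is unreadable, both of its ends sitting at the limit of > 48000 nM in this assay, at which 2 of the 2 values shown sit. Compound 2 therefore stands at the limit of this assay, not at a number. Compound 3 `C=CCn1ncc2cncn2c1=O` differs from compound 2 by hydrogen in place of propyl on an aromatic carbon. Within the data shown here, no measured step tells how removal of the propyl acts in this assay, so no direction beyond the scatter can be drawn from the measured values. Compound 3 is expected in this assay to remain at or near the limit, estimated at 60000 nM with a range from 20000 nM to 200000 nM. The expected step is a step that the limit leaves unreadable from compound 2 to compound 3.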

Compound 3, half-maximal inhibitory concentration: > 48000 nM
Compound 3: only a limit was reported (the forecaster's own chance of this, stated with the estimate: 85%); the middle value lies beyond the limit too.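

No step among compound 1, compound 2 and compound 3 can be read, since all three stand only at a limit in this assay: the limit of > 48000 nM in this assay, at which 3 of the 3 values shown sit.

The compounds shown leave open whether any group on that aromatic carbon, beyond hydrogen, ethyl and propyl, gives a readable number in this assay.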